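This account rests on a few compounds, and the source may have more. Where it says the series, first, only, none or still open, it means among the compounds named here.

Three compounds share one core and were measured in a physicochemical assay for lipophilicity; a higher number here means a more lipophilic compound, a lower number a more polar compound. Compound 1 `CCCOc1ccc2[nH]c(-c3ccccc3)c(C3=C(Br)C(=O)NC3=O)c2c1` gives 3.16, compound 2 `CCCc1ccc2[nH]c(-c3ccccc3)c(C3=C(Br)C(=O)NC3=O)c2c1` gives 3.43, and compound 3 `CCCCCCc1ccc2[nH]c(-c3ccccc3)c(C3=C(Br)C(=O)NC3=O)c2c1` gives 4.39, the highest of the three: it stands a number 0.96 log units higher from compound 2 to compound 3 (beyond the scatter) and a number 1.23 log units higher from compound 1 to compound 3 (beyond the scatter). Compound 4 `CCCCCCc1ccc2[nH]c(-c3cccc(OC)c3)c(C3=C(Br)C(=O)NC3=O)c2c1` has not yet been measured. It differs from compound 3 in one place: methoxy in place of hydrogen on an aromatic carbon. Going by the values given here, no measured step touches the same ring; the nearest comparison is a number 0.27 log units higher from compound 1 to compound 2 (within the scatter), where an oxygen is swapped out of a side chain, while the other steps only lengthen a chain. A methoxy entering an aromatic ring is therefore expected to move the number little, if at all, beyond the scatter. For compound 4 the expected value is 4.4, between 4.1 and 4.7, an expected step of a number 0.01 log units higher from compound 3 to compound 4 (within the scatter).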

Compound 4, partition coefficient: 4.26
The estimate for compound 4 lay 0.14 log units above the measured number; the range from low to high includes it.
By their numbers in this assay, from the lowest: compounds 1 and 2 (each within the scatter of the next); then compounds 4 and 3 (each within the scatter of the next).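

In this assay the change from phenyl to 3-methoxyphenyl gives a number 0.13 log units lower from compound 3 to compound 4 (within the scatter) at this aromatic carbon, so here a methoxy leaves the number within the scatter of the parent. This is the first change shown on the phenyl ring, since the earlier steps all lie in the side chain on the other side of the shared core. From the compounds shown here alone, whether an amine or a carboxylic acid at this same carbon would give a step beyond the scatter stays open. No measurement shown accounts for this result.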